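A Dimethylthiophene in Place of a Dichlorothiophene

The source may hold more compounds than are shown below. What is called first, only, known or untested is meant among the compounds shown, and "the series" means these compounds.

In a functional assay on cells (Cancer cell lines, Homo sapiens) for inhibition (a higher number here means a weaker inhibitor of growth, a lower number a stronger inhibitor of growth), compound 1 `N=C(N)N/N=C/c1c(-c2cc(Cl)sc2Cl)nc2n1CCS2` gives 15100 nM and compound 2 `Cc1cn2c(/C=N/NC(=N)N)c(-c3cccs3)nc2s1` gives 12300 nM so the two readings lie within the scatter of each other and cannot be ranked. For the measured compounds named here, compound 1 therefore stands level with the only other number available, and no measured step from a single change exists to guide the next comparison.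

Compound 3 `Cc1cc(-c2nc3n(c2/C=N/NC(=N)N)CCS3)c(C)s1` keeps the core of compound 1 and carries one change. That change is 2,5-dimethylthiophen-3-yl in place of 2,5-dichlorothiophen-3-yl on an aromatic carbon with 2,5-dimethylthiophen-3-yl in place of 2,5-dichlorothiophen-3-yl on an aromatic carbon of a five-membered aromatic ring with 2 nitrogen, next to the ring nitrogen.

In this assay no step beyond the scatter is expected, in either direction, and the estimated 1.1-fold lower number from compound 1 to compound 3 (0.03 log units; within the scatter) remains small. This expectation rests only on compound 1 at 15100 nM and compound 2 at 12300 nM as the two readings at hand, so the range is kept wide. Compound 3 is expected to read about 14000 nM with an estimated range of 6000 nM to 35000 nM in this measurement.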

Compound 3, concentration for total growth inhibition: 30900 nM
Beside the measured number, compound 3's estimate is 2.2-fold (0.34 log units) below it, within the range that was stated.
By their numbers in this assay, from the lowest: compounds 2 and 1 (each within the scatter of the next); then compound 3.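

In this assay the exchange of 2,5-dichlorothiophen-3-yl for 2,5-dimethylthiophen-3-yl gives a 2.0-fold higher number from compound 1 to compound 3 (0.31 log units; beyond the scatter), a modest step and the first measured here from a change in one place. The leaving and entering groups each hold 7 heavy atoms, one five-membered aromatic ring with 1 hetero atom, and no net charge, so the step separates chlorine from methyl on the same thiophene while the shared core stays as it is, and at this position the dichloro compound is the stronger inhibitor of growth of the pair. Nothing available bears on why the number rises with this change.

The compounds shown leave open whether chlorine and methyl each contribute to this step, since both substituents change together and no thiophene carrying one chlorine or one methyl stands among them. They also leave open how a different group on this aromatic carbon, such as a phenyl ring, a methoxy group or a carboxylic acid, would read against compound 1 in this assay.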